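Swapping 4-fluorophenyl for 3-methoxyphenyl at the assay limit

A few compounds are considered here, and "the series" means these few. Any claim that something is new, unique, unknown or untested is made for them only; others in the source may bear on it.

Of the compounds shown here, three have so far been tested in a physicochemical assay for solubility, read by HPLC, in phosphate buffer, measured as kinetic solubility, with a stated time of 1 h, at pH 7.4, tested at 250 uM; on this read-out higher numbers stand for higher solubility and lower numbers for lower solubility. Compound 1 `O=C(NCCCCc1ccccc1)n1cc(-c2ccccc2)oc1=O` gives < 1000 nM, which is a limit of the assay and not a number. Compound 2 `CCCCCNC(=O)n1cc(-c2ccccc2)oc1=O` gives < 1000 nM, again only a limit. Compound 3 `O=C(NCCCCc1ccccc1)n1cc(-c2ccc(F)cc2)oc1=O` gives < 1000 nM, also only a limit. Compound 3 therefore has no exact place on the scale, and the evidence so far is the limit of < 1000 nM in this assay, at which 3 of the 3 values shown sit.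

Compound 4 `COc1cccc(-c2cn(C(=O)NCCCCc3ccccc3)c(=O)o2)c1` differs from compound 3 in one place, with 3-methoxyphenyl in place of 4-fluorophenyl on an aromatic carbon. Going by the values given here, two measured steps bear on this change. The nearer one, a step that the two limits leave unreadable from compound 1 to compound 3, puts fluoro in place of hydrogen on an aromatic carbon. The other, a step that the two limits leave unreadable from compound 1 to compound 2, puts methyl in place of phenyl on a saturated chain carbon. Neither step has a size that can be carried over, so no change beyond the usual scatter is expected, and no direction can be given. The expected change, which is only an estimate, is a step that the limit leaves unreadable from compound 3 to compound 4. The estimate for compound 4 is 700 nM, with an expected range from 250 nM to 1500 nM.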

Compound 4, solubility: < 1000 nM
Compound 4: a limit, no number; the forecaster's own chance of this, stated with the estimate: 85%; the middle value lies beyond the limit too.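

Compound 4 gives < 1000 nM, which is a limit of the assay and not a number, so its steps from compound 3 and from compound 1 cannot be read. The result adds one more compound to the same limit: the limit of < 1000 nM in this assay, at which 4 of the 4 values shown sit.

Going by these compounds, the true value of each compound in this assay remains open, as does whether swapping 4-fluorophenyl for 3-methoxyphenyl changes it at all.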